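A Chloro Exchange on a Level Pair

The source may report more compounds than this note shows. Statements on the series, on what has been measured and on what is new or still open speak of the compounds shown alone.

In a functional assay on A549 cells (Homo sapiens) for antiproliferative activity, read by MTT assay, with a stated time of 72 h (on this read-out lower numbers stand for stronger inhibition and higher numbers for weaker inhibition), compound 1 (`O=S1(=O)C=Cc2ccc(Nc3ccc(C(F)(F)F)cc3)cc21`) gives 1140 nM as its value. Among the compounds with values here, compound 3 (`COc1ccc(Nc2ccc3c(c2)S(=O)(=O)C=C3)cc1`) gives 1220 nM within the scatter of compound 1, and these two stand level as the only numbers so far. Compound 2 (`N#Cc1cccc(Nc2ccc3c(c2)S(=O)(=O)C=C3)c1`) reads > 10000 nM as a limit of the assay and not a number.

Compound 4 (`O=S1(=O)C=Cc2ccc(Nc3ccc(Cl)cc3)cc21`) has not yet been measured. It keeps the core of compound 1 and differs in one place (chloro in place of trifluoromethyl on an aromatic carbon) where chloro takes the position of trifluoromethyl on an aromatic carbon, para to a large group. Within the data shown here, the one measured step at that place (a 1.1-fold higher number from compound 1 to compound 3 (0.03 log units; within the scatter)) puts methoxy in place of trifluoromethyl and stays within the scatter, so in this assay no change beyond the scatter is expected for chloro either. Among the measured compounds shown here, no single-place step links compound 2 to compound 1, so its limit sets no size here. A single step is thin support, and the range is kept wide for that reason. The estimated step is small (a 1.1-fold higher number from compound 1 to compound 4 (0.02 log units; within the scatter)) and lies within the scatter. The expected value for compound 4 is 1200 nM with an estimated range of 500 nM to 3000 nM on this read-out.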

Compound 4, half-maximal inhibitory concentration: 2300 nM
Compound 4: middle estimate off by 1.9-fold (0.28 log units), on the low side; low and high end bracket the measured number.
By their numbers in this assay, from the lowest: compounds 1, 3 and 4 (each within the scatter of the next). At a limit, above all of these: compound 2.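

In this assay, chloro adds two steps at this aromatic carbon, para to a large group: a 2.0-fold higher number from compound 1 to compound 4 (0.30 log units; within the scatter) and a 1.9-fold higher number from compound 3 to compound 4 (0.28 log units; within the scatter) are the new readings, and both stay within the scatter. The earlier compounds shown here offered a single exchange here, methoxy in place of trifluoromethyl, whereas compounds 1, 3 and 4 now form a set of three groups that stand level, so this place has accepted a single chlorine atom as well as the two larger groups without a step beyond the scatter. Nothing shown gives a cause for this levelness, and the one available note on the assay limit does not bear on it.

Within the data shown here, compound 2 reads > 10000 nM as a limit of the assay and not a number, and no single-place step links it to the other compounds, so what separates it from them stays open. As far as these compounds go, it also stays open whether an amine, a carboxylic acid or a longer chain on this aromatic carbon would stand level with trifluoromethyl, methoxy and chloro or would give a step beyond the scatter.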